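The compounds below may be only part of what the source reports. "The series", "measured", "known", "first", "only" and "open" are said of these compounds alone.

Notes on the series. Compound 1 `N#Cc1cccc(NC(=O)c2cc(C(F)(F)F)ccc2OCc2ccc(F)cc2)c1`, compound 2 `O=C(Nc1ccnnc1)c1cc(N2CCCC2)ccc1OCc1ccccc1` and compound 3 `CN1CCC(c2ccc(OCc3ccccc3)c(C(=O)Nc3ccnnc3)c2)CC1` have been measured in a physicochemical assay for solubility, measured as kinetic solubility; on this read-out higher numbers stand for higher solubility and lower numbers for lower solubility; compound 4 `O=C(Nc1ccnnc1)c1cc(N2CCC(O)CC2)ccc1OCc1ccccc1` has not. In this assay compound 1 gives only a limit of the assay, < 1000 nM. Compound 2 gives 35000 nM in this assay, the lowest of the two numbers shown. Compound 3 gives 71000 nM in this assay, the nearest number to compound 2, and the step between them is a 2.0-fold higher number from compound 2 to compound 3 (0.31 log units; beyond the scatter), a modest rise. Compound 4 differs from compound 2 by 4-hydroxypiperidin-1-yl in place of pyrrolidin-1-yl on an aromatic carbon. Within the data shown here, the only measured step that bears on this change is a 2.0-fold higher number from compound 2 to compound 3 (0.31 log units; beyond the scatter), where 1-methylpiperidin-4-yl replaced pyrrolidin-1-yl on an aromatic carbon. Since compound 4 likewise replaces pyrrolidin-1-yl on an aromatic carbon, this time with 4-hydroxypiperidin-1-yl, a modest step upward of similar size is expected, a 1.6-fold higher number from compound 2 to compound 4 (0.20 log units; within the scatter), given the rise seen in a 2.0-fold higher number from compound 2 to compound 3 (0.31 log units; beyond the scatter). Compound 4 is therefore estimated at 55000 nM in this assay, with a range from 20000 nM to 130000 nM.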

Compound 4, solubility: 28000 nM
Beside the measured number, compound 4's estimate is 2.0-fold (0.29 log units) above it, within the range that was stated.
By their numbers in this assay, from the lowest: compounds 4 and 2 (each within the scatter of the next); then compound 3. At a limit, below all of these: compound 1.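

In this assay there is a 1.3-fold lower number from compound 2 to compound 4 (0.10 log units; within the scatter) with 4-hydroxypiperidin-1-yl in place of pyrrolidin-1-yl, so at this position, para to a benzyloxy group, the six-membered ring with its hydrogen-bond donor leaves the number within the scatter of that of the five-membered ring. The two six-membered groups do not read alike, with a 2.5-fold lower number from compound 3 to compound 4 (0.40 log units; beyond the scatter) in place of a shared gain, so the rise seen with 1-methylpiperidin-4-yl does not extend to 4-hydroxypiperidin-1-yl. Nothing measured here gives a cause for either step.

The two six-membered groups differ both in the ring atom that carries them and in their substituent, and the compounds shown do not separate these two features. From the compounds shown here alone, how a primary amine or a carboxylic acid on this ring would read in this assay remains open.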